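Removing One Fluorine From a Selenocyanate Carbamate

This account rests on a few compounds, and the source may have more. Where it says the series, first, only, none or still open, it means among the compounds named here.

Compound 1 `CCCCOC(=O)Nc1ccc([Se]C#N)cc1`, in an ADME assay on BEAS-2B cells (Homo sapiens) for cytotoxicity, read by MTT assay, with a stated time of 72 h; on this read-out higher numbers stand for weaker inhibition of growth and lower numbers for stronger inhibition of growth: 12200 nM
Compound 2 `N#C[Se]c1ccc(NC(=O)Oc2ccc(F)cc2)cc1`, in this assay: 45600 nM

Of these two measured compounds, compound 2 shows the higher number, and its gap to compound 1 lies beyond the usual scatter of repeated measurements, so compound 2 is the weaker inhibitor of cell growth among the two.

Compound 3 `N#C[Se]c1ccc(NC(=O)Oc2ccccc2)cc1` has not yet been measured. It differs from compound 2 in one place only: hydrogen in place of fluoro on an aromatic carbon. Among the compounds with values here, no pair of measured compounds shows what such a change does here, so there is no measured step to lean on. Since only a single fluorine is lost, the step from compound 2 to compound 3 is expected to be small, a 1.1-fold lower number from compound 2 to compound 3 (0.06 log units; within the scatter), and not clearly beyond the scatter. Compound 3 is therefore estimated at 40000 nM, with a likely range from 15000 nM to 100000 nM.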

Compound 3, concentration for total growth inhibition: 38200 nM
Estimate against measurement, compound 3: 1.0-fold (0.02 log units) above, and the stated range covers the measured number.
By their numbers in this assay, from the lowest: compound 1; then compounds 3 and 2 (each within the scatter of the next).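

In this assay, hydrogen in place of fluoro on this aromatic carbon gives a 1.2-fold lower number from compound 2 to compound 3 (0.08 log units; within the scatter), so at this place the fluorine makes no difference that can be told apart from the scatter. Within the data shown here, compound 3 also links the two kinds of carbamate for the first time: phenyl in place of butyl on an oxygen next to a carbonyl group gives a 3.1-fold higher number from compound 1 to compound 3 (0.50 log units; beyond the scatter), a change that, unlike the loss of fluoro, can be read and goes with weaker inhibition of growth. Nothing measured here explains either step.

From the compounds shown here alone, it remains open whether a methoxy group or a chlorine at this place on the ring would also leave the number within the scatter. Going by these compounds, it is equally open whether a benzyl group or a longer chain on the oxygen would fall nearer to butyl or to phenyl.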